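Alpha-Methyl Branch on the Benzylic Amine: Cytotoxicity Outlook

A few compounds are considered here, and "the series" means these few. Any claim that something is new, unique, unknown or untested is made for them only; others in the source may bear on it.

The series is a set of tertiary amines built on a shared core, each carrying a tert-butylbenzyl arm and a methoxyphenyl arm. In a toxicity assay on MDCK cells (Canis lupus familiaris) for cytotoxicity, read by crystal violet staining, with a stated time of 48 h (on this read-out higher numbers stand for lower toxicity in this test and lower numbers for higher toxicity in this test), compound 3 `COc1ccc(CN(Cc2ccc(C(C)(C)C)cc2)Cc2cc3ccccc3[nH]c2=O)cc1` gives 1800 nM, the lowest of the two numbers shown. Differing from compound 3 in two places, compound 1 `COc1ccc([C@H](C)N(Cc2ccc(C(C)(C)C)cc2)Cc2cc3cc(OC)ccc3[nH]c2=O)cc1` gives 4100 nM in this assay. Compound 2 `COc1ccc([C@H](C)N(Cc2ccc(C(C)(C)C)cc2)Cc2cc3cc(C(C)C)ccc3[nH]c2=O)cc1` in this assay returns only a limit, > 10000 nM, and the limit of > 10000 nM in this assay, at which 1 of the 3 values shown sits, marks where it sits. Among the measured compounds shown here, the one measured step, an at least 2.4-fold higher number from compound 1 to compound 2 (0.38 log units; beyond the scatter), concerns the core substituent and not the amine arm. Compound 4 `COc1ccc([C@H](C)N(Cc2ccc(C(C)(C)C)cc2)Cc2cc3ccccc3[nH]c2=O)cc1` differs from compound 3 by methyl in place of hydrogen on a saturated chain carbon bound to an amine nitrogen and an aromatic carbon. For the measured compounds named here, no measured step bears directly on this change, so the expectation rests on the spread of the numbers seen. A modest rise is expected, and for compound 4 the estimate in this assay is 3000 nM, ranging from 1200 nM to 8000 nM. This estimate corresponds to an expected step of a 1.7-fold higher number from compound 3 to compound 4 (0.22 log units; within the scatter).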

Compound 4, half-maximal cytotoxic concentration: 1800 nM
Beside the measured number, compound 4's estimate is 1.7-fold (0.22 log units) above it; measured number inside the range.
By their numbers in this assay, from the lowest: compounds 3 and 4 (each within the scatter of the next); then compound 1. At a limit, above all of these: compound 2.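

In this assay, methyl in place of hydrogen on the saturated chain carbon bound to an amine nitrogen and an aromatic carbon leaves the read-out unmoved on the unsubstituted core, with no change at the digits printed from compound 3 to compound 4 (within the scatter), so this branch alone does not account for the higher numbers of the branched compounds. With the branch held in place, the core substituent separates them instead, with a 2.3-fold lower number from compound 1 to compound 4 (0.36 log units; beyond the scatter) and an at least 5.5-fold lower number from compound 2 to compound 4 (0.74 log units; beyond the scatter), the second step resting on a limit and not on a number. Compound 2 therefore fixes only one end of the comparison, its value being a limit: the limit of > 10000 nM in this assay, at which 1 of the 4 values shown sits.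

From the compounds shown here alone, whether the branch would also leave the read-out unmoved on the cores of compound 1 and compound 2 stays open. So does how an ethyl on that chain carbon, or an amine or a carboxylic acid in place of the core's methoxy, would read in this assay.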